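The compounds below may be only part of what the source reports. "The series", "measured", "known", "first", "only" and "open" are said of these compounds alone.

Working notes on the series

Compound 3 `CC1(O)CCN(C(=O)OCCn2nnnc2[C@@H](COCc2ccccc2)NC(=O)C(C)(C)N)C1` gives 10.1 nM in a functional assay on H4 cells with growth hormone secretagogue receptor type 1 (Homo sapiens) as the target, read by FLIPR (a higher number here means that more compound is needed for the effect, a lower number that less compound is needed), and stands at the highest number of the three measured. Its nearest neighbour is compound 1 `CC(C)(N)C(=O)N[C@H](COCc1ccccc1)c1nnnn1CCOC(=O)NCCCO` with 5.5 nM in this assay; the step of a 1.8-fold higher number from compound 1 to compound 3 (0.26 log units; within the scatter) is within the scatter. Furthest is compound 2 `CC(C)(N)C(=O)N[C@H](COCc1ccccc1)c1nnnn1CCOC(=O)N1CC[C@@H](O)C1`, which gives 1 nM in this assay; the step of a 10-fold higher number from compound 2 to compound 3 (1.00 log units; beyond the scatter) is beyond the scatter.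

Compound 4 `CC(=O)N[C@@H]1CCN(C(=O)OCCn2nnnc2[C@@H](COCc2ccccc2)NC(=O)C(C)(C)N)C1` is not yet measured. Relative to compound 3 the change is 3-acetamidopyrrolidin-1-yl in place of 3-hydroxy-3-methylpyrrolidin-1-yl on a carbonyl carbon.

Going by the values given here, two measured steps bear on this. The step of a 10-fold higher number from compound 2 to compound 3 (1.00 log units; beyond the scatter) shows that exchanging the substituents on the pyrrolidine ring can move the number in this assay by a modest amount, and the step of a 5.5-fold lower number from compound 1 to compound 2 (0.74 log units; beyond the scatter) shows a modest move in the other direction when the 3-hydroxypyrrolidin-1-yl group enters. From the compounds shown here alone, compound 4 carries a pyrrolidine without the methyl, so a return toward the lower numbers of compound 1 and compound 2 is expected, though the acetamido group is untested. For compound 4 the expected step is a 2.0-fold lower number from compound 3 to compound 4 (0.31 log units; beyond the scatter), and the estimate is 5 nM with a range from 1.5 nM to 20 nM.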

Compound 4, half-maximal effective concentration: 3.3 nM
Estimate against measurement, compound 4: 1.5-fold (0.18 log units) above, and the stated range covers the measured number.
By their numbers in this assay, from the lowest: compound 2; then compounds 4, 1 and 3 (each within the scatter of the next, the first and the last beyond it).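

At the carbonyl carbon whose other neighbour is oxygen next to a carbonyl group, this assay accepts an acetamido-bearing ring: 3-acetamidopyrrolidin-1-yl in place of 3-hydroxy-3-methylpyrrolidin-1-yl gives a 3.1-fold lower number from compound 3 to compound 4 (0.49 log units; beyond the scatter), so this position is not limited to hydroxy-bearing groups. On the same ring, acetamido in place of hydroxy gives a 3.3-fold higher number from compound 2 to compound 4 (0.52 log units; beyond the scatter), which leaves the hydroxy of compound 2 ahead, while a 1.7-fold lower number from compound 1 to compound 4 (0.22 log units; within the scatter) does not separate the acetamido ring from the open (3-hydroxypropyl)amino chain. Nothing shown gives a reason for any of these steps.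

Open, from the compounds shown here alone, is whether an amine or a carboxylic acid on that ring carbon would keep the number low. Also open, going by these compounds, is what the opposite configuration at the acetamido-bearing carbon would give.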